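Chain extension on the urea side of the sulfonate series

A few compounds are considered here, and "the series" means these few. Any claim that something is new, unique, unknown or untested is made for them only; others in the source may bear on it.

Compound 1 `CC(=O)Nc1ccc(S(=O)(=O)Oc2ccccc2C(C)C)cc1`, compound 2 `CCCC(=O)Nc1ccc(S(=O)(=O)Oc2ccccc2C(C)C)cc1` and compound 3 `CCCNC(=O)Nc1ccc(S(=O)(=O)Oc2ccccc2C(C)C)cc1` share one core and differ only in the group carried on the carbonyl carbon. In a functional assay on HT-29 cells (Homo sapiens) for antiproliferative activity, read by sulforhodamine B assay, with a stated time of 48 h (a higher number here means a weaker inhibitor, a lower number a stronger inhibitor), compound 1 gives 23000 nM, compound 2 gives 4900 nM and compound 3 gives 6300 nM. Compound 3 thus stands second highest of the three numbers; its nearest neighbour is compound 2, with a 1.3-fold higher number from compound 2 to compound 3 (0.11 log units; within the scatter), and its furthest is compound 1, with a 3.7-fold lower number from compound 1 to compound 3 (0.56 log units; beyond the scatter).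

Compound 4 `CCCCCNC(=O)Nc1ccc(S(=O)(=O)Oc2ccccc2C(C)C)cc1` takes the change (ethyl in place of hydrogen on a saturated chain carbon, three bonds along the chain from an amide-type nitrogen). The measured step that bears on it most is a 4.7-fold lower number from compound 1 to compound 2 (0.67 log units; beyond the scatter), the same lengthening of a chain, there on a carbon bound to the carbonyl carbon rather than three bonds along the chain from the amide-type nitrogen; the step of a 1.3-fold higher number from compound 2 to compound 3 (0.11 log units; within the scatter) shows that exchanging the carbonyl substituent itself made little difference. Within the data shown here, a lowering of comparable or somewhat smaller size is expected, with the caution that only one such step exists. Compound 4 is expected to give 3500 nM in this assay, within 1500 nM to 8000 nM, an expected step of a 1.8-fold lower number from compound 3 to compound 4 (0.26 log units; within the scatter).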

Compound 4, half-maximal inhibitory concentration: 4900 nM
For compound 4 the middle estimate is 1.4-fold (0.15 log units) below the measured one, and the stated range covers the measured number.
By their numbers in this assay, from the lowest: compounds 2, 4 and 3 (each within the scatter of the next); then compound 1.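

Ethyl in place of hydrogen, three bonds along the chain from an amide-type nitrogen, does not separate pentylamino from propylamino on the carbonyl carbon (a 1.3-fold lower number from compound 3 to compound 4 (0.11 log units; within the scatter)) in this assay. Pentylamino also stays level with propyl on the carbonyl carbon (no change at the digits printed from compound 2 to compound 4 (within the scatter)), while it keeps a modest step over methyl (a 4.7-fold lower number from compound 1 to compound 4 (0.67 log units; beyond the scatter)), so the longer chain in compound 4 adds nothing beyond the scatter to what compound 2 and compound 3 already show. The same chain lengthening therefore does not carry over from one place to the other: the same change on two cores in this assay, a 4.7-fold lower number (0.67 log units; beyond the scatter) from compound 1 to compound 2 and a 1.3-fold lower number (0.11 log units; within the scatter) from compound 3 to compound 4, 3.7-fold (0.56 log units) apart, beyond the scatter of two such steps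

From the compounds shown here alone, whether a chain longer than pentyl would move the number beyond the scatter remains open. So does the effect of an amine or a carboxylic acid carried on this chain.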